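The source may report more compounds than this note shows. Statements on the series, on what has been measured and on what is new or still open speak of the compounds shown alone.

The measured compounds are:
compound 1, `COc1ccc(-c2ccnc(Nc3ccc(C(N)=O)cc3)n2)cc1`, which in a functional assay on A549 cells (Homo sapiens) for cytotoxicity, read by MTT assay, with a stated time of 72 h (a lower number here means a stronger inhibitor, a higher number a weaker inhibitor), gives 5300 nM;
compound 2, `COc1ccc(-c2ccnc(Nc3ccc(S(N)(=O)=O)cc3)n2)cc1`, which in this assay gives 4400 nM;
compound 3, `CC(=O)Nc1ccc(-c2ccnc(Nc3cccc(S(N)(=O)=O)c3)n2)cc1`, which in this assay gives 6600 nM.

All three numbers lie within the scatter of one another, so no order among them is claimed. Compound 4, `CC(=O)Nc1ccc(-c2ccnc(Nc3cccc(C(N)=O)c3)n2)cc1`, has not yet been measured in this assay. It differs from compound 3 in one place: carbamoyl in place of sulfamoyl on an aromatic carbon. The same kind of change has already been measured once, from compound 2 to compound 1: carbamoyl in place of sulfamoyl on an aromatic carbon. That step was a 1.2-fold higher number from compound 2 to compound 1 (0.08 log units; within the scatter). The two places are not identical: in compound 2 the group is para to a large group, in compound 3 it is meta to a large group, so the change is the same kind of change rather than the same. The difference between the core of compound 3 and the core of compound 2 is not broken down here; their two values are within the scatter of each other.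

For compound 4 the expected step is a 1.1-fold higher number from compound 3 to compound 4 (0.06 log units; within the scatter), because the earlier 1.2-fold higher number from compound 2 to compound 1 (0.08 log units; within the scatter) was within the scatter and gives no reason to expect more from the same kind of change at a place that is meta rather than para to a large group. Compound 4 is therefore estimated at 7500 nM in this assay, with a range from 3500 nM to 16000 nM.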

Compound 4, half-maximal inhibitory concentration: 33000 nM
Estimate against measurement, compound 4: 4.4-fold (0.64 log units) below, outside the stated range (above it).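

In this assay, putting carbamoyl in place of sulfamoyl on the core of compound 3, meta to a large group, gives a 5.0-fold higher number from compound 3 to compound 4 (0.70 log units; beyond the scatter), a step beyond the scatter. Set beside the earlier case, the same kind of change did not keep its size from one core to the other: the same change on two cores in this assay, a 1.2-fold higher number (0.08 log units; within the scatter) from compound 2 to compound 1 and a 5.0-fold higher number (0.70 log units; beyond the scatter) from compound 3 to compound 4, 4.2-fold (0.62 log units) apart, beyond the scatter of two such steps. For the compounds shown here, this shows that, in this series, a small step on one core does not ensure a small step on another, but it does not show what sets the two apart, since the two pairs differ at once in the rest of the core and in where the group sits on its ring, and with only one pair on each core it gives no rule for any further core.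

The compounds shown leave open whether the larger step follows the place of the group or the rest of the core, which a pair with the methoxy-bearing core and the group meta to a large group could help to separate. They also leave open how another group at that same place, such as a carboxylic acid or an amine, would compare with sulfamoyl and carbamoyl in this assay.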